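The compounds below may be only part of what the source reports. "The series", "measured", "known", "first", "only" and "open" are said of these compounds alone.

Of the compounds shown here, three built on one shared core have been measured. Compound 1 `Cc1ccc(NC2=CC(=O)c3nc4n(c3C2=O)[C@H]2OC[C@@H](O)[C@H]2OC4)cc1C` carries a 3,4-dimethylphenyl group on its amine nitrogen. In a functional assay on ECa-109 cells for inhibition, with ECa-109 cell line (Homo sapiens) as the target, read by sulforhodamine B assay (a higher number here means a weaker inhibitor, a lower number a stronger inhibitor), compound 1 gives 2820 nM. Compound 3 `COc1ccc(NC2=CC(=O)c3nc4n(c3C2=O)[C@H]2OC[C@@H](O)[C@H]2OC4)cc1` carries a 4-methoxyphenyl group in the same position. In this assay compound 3 gives > 4000 nM, which is a limit of the assay and not a number. The step of an at least 1.4-fold higher number from compound 1 to compound 3 (0.15 log units; that floor lies within the scatter) is therefore only a floor, and it lies within the scatter.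

Compound 2 `CCCc1ccc(NC2=CC(=O)c3c(nc4n3[C@H]3OC[C@@H](O)[C@H]3OC4)C2=O)cc1` carries a 4-propylphenyl group on the amine nitrogen. In this assay compound 2 gives > 4000 nM, a limit of the assay rather than a number. Compound 2 thus stands at the limit of > 4000 nM in this assay, at which 2 of the 3 values shown sit.

Compound 4 `O=C1C(Nc2ccc(I)cc2)=CC(=O)c2c1nc1n2[C@H]2OC[C@@H](O)[C@H]2OC1` differs from compound 2 in one place: iodo in place of propyl on an aromatic carbon. Going by the values given here, no measured step concerns this change; the single step, from compound 1 to compound 3, alters the anilino substituent in a different way and itself stays within the scatter. Nothing in the measured compounds points to a direction for the step from compound 2 to compound 4, so no step beyond the scatter is expected in this assay.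

Compound 4 is therefore expected to give about 5000 nM, between 2000 nM and 12000 nM, the expected step being a step that the limit leaves unreadable from compound 2 to compound 4.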

Compound 4, half-maximal inhibitory concentration: 2530 nM
Beside the measured number, compound 4's estimate is 2.0-fold (0.30 log units) above it; the measured number falls inside the stated range.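

With iodo in place of propyl, the position that carries the propyl group in compound 2 gives a readable number: in this assay compound 4 gives 2530 nM, so with a single iodine atom in place of a chain of three carbons the value can be read. What can be read of this change is an at least 1.5-fold lower number from compound 2 to compound 4 (0.19 log units; that floor lies within the scatter), so the change is shown only as a floor, and that floor does not establish a difference beyond the scatter. The size of the step stays unknown because the value of compound 2 is a limit of the assay and not a number: the limit of > 4000 nM in this assay, at which 2 of the 4 values shown sit.

The compounds shown leave open how far compound 2 actually lies from compound 4, and so whether iodo and propyl differ at all at this position in this assay. They also leave open what chloro, bromo, an amine or a carboxylic acid would give on the same aromatic carbon.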